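A Nitro-to-Hydrogen Step on a Shared Ester Core

A few compounds are considered here, and "the series" means these few. Any claim that something is new, unique, unknown or untested is made for them only; others in the source may bear on it.

Measured so far:
Compound 1 `CC1(C)C2CCC1(C)C(OC(=O)/C=C/c1cc(O)c(O)c(Cl)c1)C2` gives 38700 nM.
Compound 2 `CC1(C)C2CCC1(C)C(OC(=O)/C=C/c1ccc(O)c(O)c1[N+](=O)[O-])C2` gives 13900 nM.

Both were tested in a functional assay on HeLa cells (Homo sapiens) for inhibition, read by MTT assay; a lower number here means a stronger inhibitor, a higher number a weaker inhibitor. Compound 2 stands at the lowest of the two numbers; compound 1 sits higher, by a gap beyond the usual scatter. Compound 3 `CC1(C)C2CCC1(C)C(OC(=O)/C=C/c1ccc(O)c(O)c1)C2` has not yet been measured. It differs from compound 2 in one place: hydrogen in place of nitro on an aromatic carbon. Within the data shown here, no step between measured compounds covers this change, so the expectation rests on little. The step expected here, a 1.6-fold higher number from compound 2 to compound 3 (0.20 log units; within the scatter), is a modest one, likely within the scatter. Compound 3 is estimated at 22000 nM, with a range from 7000 nM to 70000 nM.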

Compound 3, half-maximal inhibitory concentration: 20600 nM
Estimate against measurement, compound 3: 1.1-fold (0.03 log units) above; the range from low to high includes it.
By their numbers in this assay, from the lowest: compounds 2, 3 and 1 (each within the scatter of the next, the first and the last beyond it).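

In this assay (this assay), hydrogen in place of nitro gives a step within the scatter (a 1.5-fold higher number from compound 2 to compound 3 (0.17 log units; within the scatter)), so at this aromatic carbon, ortho to a hydroxy group, the two cannot be told apart. Hydrogen in place of chloro on an aromatic carbon also stays within the scatter (a 1.9-fold lower number from compound 1 to compound 3 (0.27 log units; within the scatter)). Nothing available explains either step. As far as these compounds go, it remains open whether an amine, a methoxy group or a carboxylic acid on this carbon would move the number beyond the scatter. From the compounds shown here alone, the role of the two hydroxy groups also remains open.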